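This account rests on a few compounds, and the source may have more. Where it says the series, first, only, none or still open, it means among the compounds named here.

Two members of the series have been run in a functional assay on the whole organism (strain albino) for inhibition, with Rattus norvegicus as the target, read by paw edema, with stated times of 30 min and 1 h, at a dose of 0.28 mmol/kg by the oral route; a higher number here means more inhibition at the dose given (going by the name of the read-out), a lower number less inhibition. Compound 1 `CCn1c(SCC(=O)Nc2ccc(/C(C)=N/O)cc2)nnc1-c1ccc(OC)c(OC)c1` gives 53% there, and compound 2 `COc1ccc(-c2nnc(SCC(=O)Nc3ccc(/C(C)=N/O)cc3)n2-c2ccccc2)cc1` gives 45%. Within the data shown here, compound 2 thus holds the lower of the two numbers, but its gap to compound 1 lies within the usual scatter, so no order between the two follows from these figures; the two compounds also differ in more than one place, so no single step is defined between them. Compound 3 `CCn1c(SCC(=O)Nc2ccc(/C(C)=N/O)cc2)nnc1-c1ccc(OC)cc1` has not been measured yet. Its difference from compound 2 is ethyl in place of phenyl on an aromatic nitrogen. Compound 1 carries the same ethyl group, and its value in this assay sits within the scatter of compound 2, so no step beyond the scatter is expected here. The expected step is a number 5 percentage points higher from compound 2 to compound 3 (within the scatter), a change of no real size. For compound 3 the estimated value in this assay is 50%, within a range from 36% to 64%.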

Compound 3, a percentage reported as inhibition, in the whole organism at one dose (the size of the read-out at that dose, not a potency): 54%
For compound 3 the middle estimate is 4 percentage points below the measured one, within the range that was stated.
By their numbers in this assay, from the lowest: compounds 2, 1 and 3 (each within the scatter of the next).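

Ethyl in place of phenyl on the aromatic nitrogen gives, in this assay, a number 9 percentage points higher from compound 2 to compound 3 (within the scatter), so this nitrogen accepts a small open chain in place of the six-membered aromatic ring with no step of real size at this dose. Among these compounds, the second single change, hydrogen in place of methoxy on an aromatic carbon, gives a number 1 percentage points higher from compound 1 to compound 3 (within the scatter), so the inhibition read-out also shows no real step at this site. Nothing available bears on the reason for either result.

As far as these compounds go, whether a longer chain such as n-butyl, a benzyl group or a chain carrying an amine on this nitrogen would move the read-out beyond the scatter remains open. A reading at one dose also leaves the relative potency of these compounds open.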